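A few compounds are considered here, and "the series" means these few. Any claim that something is new, unique, unknown or untested is made for them only; others in the source may bear on it.

Measured so far in an ADME assay on MT4 cells (Homo sapiens) for cytotoxicity, read by MTT assay, with a stated time of 96 h; a higher number here means that more compound is tolerated, a lower number that less compound is tolerated:

Compound 1, `CN1CCN(CC(=O)Nc2ccc(-c3nc4cc(C(F)(F)F)ccc4n3C)cc2)CC1`, gives 22000 nM.
Compound 2, `CCN(CC)CC(=O)Nc1ccc(-c2nc3cc(C(F)(F)F)ccc3n2C)cc1`, gives 9000 nM.
Compound 3, `Cn1c(-c2ccc(NC(=O)CN3CCN(c4ccccc4)CC3)cc2)nc2cc(C(F)(F)F)ccc21`, gives 1500 nM.

Compound 3 stands lowest of the three in this assay; its nearest neighbour is compound 2, a 6.0-fold lower number from compound 2 to compound 3 (0.78 log units; beyond the scatter), and the furthest is compound 1, a 15-fold lower number from compound 1 to compound 3 (1.17 log units; beyond the scatter). The step to compound 1 with diethylamino in the same place was smaller, a 2.4-fold lower number from compound 1 to compound 2 (0.39 log units; beyond the scatter).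

Compound 4, `Cn1c(-c2ccc(NC(=O)CN3CCCCC3)cc2)nc2cc(C(F)(F)F)ccc21`, differs from compound 3 by piperidin-1-yl in place of 4-phenylpiperazin-1-yl on a saturated chain carbon bound to a carbonyl carbon. The two steps that bear on it are those that end at compound 3: the exchange of methyl for phenyl on the ring amine nitrogen, a 15-fold lower number from compound 1 to compound 3 (1.17 log units; beyond the scatter), and the exchange of diethylamino for 4-phenylpiperazin-1-yl, a 6.0-fold lower number from compound 2 to compound 3 (0.78 log units; beyond the scatter). Both steps that bring in the phenyl-bearing ring lower the number by a modest-to-large amount; removing the phenyl and the second ring nitrogen together is expected to run the other way, toward the numbers of compound 1 and compound 2. For compound 4 in this assay the estimate is therefore a higher number, a 6.7-fold higher number from compound 3 to compound 4 (0.82 log units; beyond the scatter), giving 10000 nM with a range from 4000 nM to 25000 nM.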

Compound 4, half-maximal cytotoxic concentration: 9000 nM
For compound 4 the middle estimate is 1.1-fold (0.05 log units) above the measured one, and the stated range covers the measured number.
By their numbers in this assay, from the lowest: compound 3; then compounds 2 and 4 (each within the scatter of the next); then compound 1.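

In this assay, taking out 4-phenylpiperazin-1-yl for piperidin-1-yl on the saturated chain carbon bound to a carbonyl carbon gives a 6.0-fold higher number from compound 3 to compound 4 (0.78 log units; beyond the scatter) and so ties the low number of compound 3 to that group, not to any ring amine at this place. Piperidin-1-yl in place of diethylamino gives no change at the digits printed from compound 2 to compound 4 (within the scatter) and piperidin-1-yl in place of 4-methylpiperazin-1-yl gives a 2.4-fold lower number from compound 1 to compound 4 (0.39 log units; beyond the scatter), leaving compound 1 highest of the four, although compound 3 also carries a second ring nitrogen and goes against any reading of that nitrogen alone. No measurement on hand accounts for these steps.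

The compounds shown leave open whether a benzyl or a pyridyl on the ring amine nitrogen follows phenyl, and whether a morpholine follows piperidin-1-yl. Going by these compounds, how a longer chain would read at this place also stays open.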